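Piperidine replacements for the pyrrolidine of compound 1

The source may report more compounds than this note shows. Statements on the series, on what has been measured and on what is new or still open speak of the compounds shown alone.

Compound 1 `COc1cc2c(Nc3ccc(C#N)cc3)ncnc2cc1OCCCN1CCCC1` gives 21800 nM in a functional assay on A549 cells (Homo sapiens) for antiproliferative activity, read by MTT assay, with a stated time of 72 h; on this read-out lower numbers stand for stronger inhibition and higher numbers for weaker inhibition. Among the compounds with values here, of the two numbers measured so far it is the lowest; its nearest neighbour is compound 2 `COc1cc2c(Nc3ccc(C#N)cc3)ncnc2cc1OCCCN1CCC(O)CC1`, which in this assay gives 29900 nM, a step of a 1.4-fold higher number from compound 1 to compound 2 (0.14 log units; within the scatter). Compound 3 `COc1cc2c(Nc3ccc(C#N)cc3)ncnc2cc1OCCCN1CCC(CO)CC1` reaches only a limit of the assay in this assay, > 100000 nM. Against compound 1 this reads as an at least 4.5-fold higher number from compound 1 to compound 3 (0.66 log units; beyond the scatter), and against compound 2 as an at least 3.3-fold higher number from compound 2 to compound 3 (0.52 log units; beyond the scatter); it is the limit of > 100000 nM in this assay, at which 1 of the 3 values shown sits, and not a number.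

Compound 4 `COc1cc2c(Nc3ccc(C#N)cc3)ncnc2cc1OCCCN1CCC(N(C)C)CC1` has not yet been measured. It differs from compound 1 by 4-(dimethylamino)piperidin-1-yl in place of pyrrolidin-1-yl on a saturated chain carbon, three bonds along the chain from an oxygen on an aromatic ring. Within the data shown here, two measured steps bear on this change, both replacing the same pyrrolidin-1-yl with a substituted piperidin-1-yl: the step of a 1.4-fold higher number from compound 1 to compound 2 (0.14 log units; within the scatter) stayed within the scatter, while the step of an at least 4.5-fold higher number from compound 1 to compound 3 (0.66 log units; beyond the scatter) went beyond it toward weaker inhibition. Among the measured compounds shown here, no measured step introduces a dimethylamino group, so the size expected in this assay is either none beyond the scatter or a modest rise, not a fall. Compound 4 is therefore estimated at 30000 nM, between 12000 nM and 80000 nM, which means an expected step of a 1.4-fold higher number from compound 1 to compound 4 (0.14 log units; within the scatter).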

Compound 4, half-maximal inhibitory concentration: 42400 nM
Compound 4: the middle estimate sits 1.4-fold (0.15 log units) below what was measured; the measured number falls inside the stated range.
By their numbers in this assay, from the lowest: compounds 1, 2 and 4 (each within the scatter of the next). At a limit, above all of these: compound 3.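

In this assay, the change from pyrrolidin-1-yl to the larger 4-(dimethylamino)piperidin-1-yl, on a saturated chain carbon three bonds along the chain from an oxygen on an aromatic ring, stays within the scatter (a 1.9-fold higher number from compound 1 to compound 4 (0.29 log units; within the scatter)), and the swap of hydroxy for dimethylamino on the same ring carbon does too (a 1.4-fold higher number from compound 2 to compound 4 (0.15 log units; within the scatter)). A piperidine with a substituent on that ring carbon therefore does not by itself raise the number, with compound 3 going against this, and dimethylamino in place of hydroxymethyl moves beyond the scatter (an at least 2.3-fold lower number from compound 3 to compound 4 (0.37 log units; beyond the scatter)). That step starts from compound 3, whose entry is a limit of the assay and not a number, so its true size stays unknown: the limit of > 100000 nM in this assay, at which 1 of the 4 values shown sits.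

With compounds 1, 2 and 4 all within the scatter of one another, the series shows no gain in inhibition from any of these ring changes, and all three numbers remain high. Still open, on these data alone, is whether the hydroxymethyl result reflects the extra carbon between ring and substituent, which a 4-(dimethylaminomethyl)piperidin-1-yl group would test, and how a morpholine, a 4-methylpiperazine or a shorter two-carbon chain would read.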